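Adding chloro to compound 3: expected growth inhibition

The source may report more compounds than this note shows. Statements on the series, on what has been measured and on what is new or still open speak of the compounds shown alone.

Compound 1 `CC(=O)OC/C(=C\c1ccc(Cl)cc1Cl)C(=O)c1ccccc1` gives 3500 nM in a functional assay on SW1573 cells (Homo sapiens) for inhibition, read by sulforhodamine B assay, with a stated time of 48 h; on this read-out higher numbers stand for weaker inhibition of growth and lower numbers for stronger inhibition of growth.
Compound 2 `CC(=O)OC/C(=C/c1ccccc1Cl)C(=O)c1ccccc1` gives 14000 nM in this assay.
Compound 3 `CC(=O)OC/C(=C/c1ccc(Cl)cc1Cl)C(=O)c1ccccc1` gives 22000 nM in this assay.

Compound 3 holds the highest of the three numbers: a 6.3-fold higher number from compound 1 to compound 3 (0.80 log units; beyond the scatter), a step that goes with the fact that compounds 1 and 3 differ only in the configuration as drawn, and a 1.6-fold higher number from compound 2 to compound 3 (0.20 log units; within the scatter). Compound 4 `CC(=O)OC/C(=C/c1ccc(Cl)cc1Cl)C(=O)c1ccc(Cl)cc1` differs from compound 3 by chloro in place of hydrogen on an aromatic carbon. For the measured compounds named here, the one measured step that bears on this is a 1.6-fold higher number from compound 2 to compound 3 (0.20 log units; within the scatter), likewise chloro in place of hydrogen on an aromatic carbon, though on the other ring. On that basis no step beyond the scatter is expected, and the estimated change is no change at the digits printed from compound 3 to compound 4 (within the scatter). Compound 4 is therefore expected to give about 22000 nM, within a range from 8000 nM to 55000 nM.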

Compound 4, concentration for 50% growth inhibition: 21000 nM
Compound 4: middle estimate off by 1.0-fold (0.02 log units), on the high side; measured number inside the range.
By their numbers in this assay, from the lowest: compound 1; then compounds 2, 4 and 3 (each within the scatter of the next).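

In this assay, for the compounds shown here, the change from phenyl to 4-chlorophenyl gives a 1.0-fold lower number from compound 3 to compound 4 (0.02 log units; within the scatter), the first reading of a chloro group on this ring, on an aromatic carbon para to a large group. Like a 1.6-fold higher number from compound 2 to compound 3 (0.20 log units; within the scatter), on the other ring, this step stays within the scatter, so neither chloro placement shown moves compound 3 or its neighbours measurably. Nothing at hand bears on why this step is so small.

As far as these compounds go, whether an amine or a carboxylic acid at this place would read the same remains open. So does whether chloro here would leave the number unmoved on the double-bond configuration of compound 1.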